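Swapping the sulfonyl aryl group in a limit-bound series

This account rests on a few compounds, and the source may have more. Where it says the series, first, only, none or still open, it means among the compounds named here.

Measured so far in an assay on isolated protein for inhibition of malate dehydrogenase, mitochondrial (Sus scrofa), with stated times of 45 min and 30 min; on this read-out lower numbers stand for stronger inhibition and higher numbers for weaker inhibition:
Compound 1 `O=S(=O)(Nc1ccc(-c2nc3ccccc3o2)cc1)c1cccc(F)c1` gives > 63000 nM, a limit of the assay.
Compound 2 `COc1ccc(S(=O)(=O)Nc2ccc(-c3nc4ccccc4o3)cc2)cc1` gives > 63000 nM, also a limit.

Both results sit at the same limit (the limit of > 63000 nM in this assay, at which 2 of the 2 values shown sit), so the step that the two limits leave unreadable from compound 1 to compound 2 cannot be read. Compound 2 therefore stands at the limit, with no number to anchor it. Compound 3 `Cc1ccccc1S(=O)(=O)Nc1ccc(-c2nc3ccccc3o2)cc1` differs from compound 2 by 2-methylphenyl in place of 4-methoxyphenyl on a sulfonyl sulfur. Going by the values given here, the one measured step is unreadable in size, so no step beyond the scatter can be foreseen in this assay, and the most likely outcome is another limit. Compound 3 is expected at 63000 nM, with a range from 20000 nM to 200000 nM. The expected step is a number no higher from compound 2 to compound 3 (the limit leaves the size open).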

Compound 3, half-maximal inhibitory concentration: > 63000 nM
Compound 3: no number, only a limit (the forecaster's own chance of this, stated with the estimate: 85%); the middle value lies on the limit itself.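

Compound 3 also ends at a limit, so the steps among compound 1, compound 2 and compound 3 cannot be read: the limit of > 63000 nM in this assay, at which 3 of the 3 values shown sit. The compounds shown leave open whether changing the group on the sulfonyl sulfur alters inhibition at all.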